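A few compounds are considered here, and "the series" means these few. Any claim that something is new, unique, unknown or untested is made for them only; others in the source may bear on it.

Compound 3 `O=C1c2ccccc2C(=O)N1C/C=C\Cn1cc(C#Cc2ccc(Br)cc2)c(=O)[nH]c1=O` stands at the top of the two numbers that have been obtained so far: in a functional assay on HeLa cells (Homo sapiens) for antiproliferative activity, read by MTT assay, with a stated time of 3 days (on this read-out lower numbers stand for stronger inhibition and higher numbers for weaker inhibition), compound 3 gives 87000 nM. Its nearest neighbour, compound 2 `CCCCCCCCC#Cc1cn(C/C=C\CN2C(=O)c3ccccc3C2=O)c(=O)[nH]c1=O`, gives 59000 nM in this assay, and a 1.5-fold higher number from compound 2 to compound 3 (0.17 log units; within the scatter). Compound 1 `Cc1ccc(C#Cc2cn(C/C=C\CN3C(=O)c4ccccc4C3=O)c(=O)[nH]c2=O)cc1` reaches only a limit of this assay, > 100000 nM. The next compound, compound 4 `CCCCCc1ccc(C#Cc2cn(C/C=C\CN3C(=O)c4ccccc4C3=O)c(=O)[nH]c2=O)cc1`, differs from compound 3 by pentyl in place of bromo on an aromatic carbon. Among the compounds with values here, two measured steps bear on this: an at least 1.1-fold lower number from compound 1 to compound 3 (0.06 log units; that floor lies within the scatter) exchanged one small substituent on the same aromatic carbon, and an at least 1.6-fold lower number from compound 1 to compound 2 (0.22 log units; that floor lies within the scatter) traded the whole aryl group for a plain chain. Neither left the scatter, so for compound 4 no step beyond the scatter is expected, a 1.5-fold lower number from compound 3 to compound 4 (0.16 log units; within the scatter). Compound 4 is therefore estimated at 60000 nM, with a range from 20000 nM to 150000 nM.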

Compound 4, half-maximal inhibitory concentration: > 100000 nM
Compound 4: a limit, no number; the forecaster's own chance of this, stated with the estimate: 35%; at least 1.6-fold (0.22 log units) between middle value and limit.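

Putting pentyl in place of bromo on this aromatic carbon gives an at least 1.1-fold higher number from compound 3 to compound 4 (0.06 log units; that floor lies within the scatter), so the larger chain shows no sign of stronger inhibition at this position. Carrying a chain on the aryl group rather than directly on the triple-bonded carbon gives an at least 1.6-fold higher number from compound 2 to compound 4 (0.22 log units; that floor lies within the scatter), which also does not establish a real difference. Compound 1 and compound 4 are both limits, so the step between them cannot be read, and the series now gathers at one end of the range: the limit of > 100000 nM in this assay, at which 2 of the 4 values shown sit.

Going by these compounds, whether an amine or a carboxylic acid on this aromatic carbon would give a number clearly lower than that of compound 3 stays open. So does whether a chain longer than octyl on the triple-bonded carbon would move the number beyond the scatter.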